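Replacing Bromo with a Fluoropyridinyl Ring

This account rests on a few compounds, and the source may have more. Where it says the series, first, only, none or still open, it means among the compounds named here.

Compound 1 `COc1cc(OC)c2c(=O)cc(-c3ccc(OCCBr)cc3)oc2c1` and compound 2 `COc1cc(OC)c2c(=O)cc(-c3ccc(Br)cc3)oc2c1` share one core and differ only at one aromatic carbon. In a functional assay (Homo sapiens) for antiproliferative activity, read by resazurin assay, with a stated time of 48 h, tested at 20 uM (a higher number here means a stronger effect of the compound at the concentration tested, a lower number a weaker effect), compound 1 gives 20%, and in this assay compound 2 gives 22%. The step of a number 2 percentage points higher from compound 1 to compound 2 (within the scatter) places the two within the scatter of each other, so compound 2 stands alongside compound 1 rather than apart from it.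

Compound 3 `COc1cc(OC)c2c(=O)cc(-c3ccc(-c4ccc(F)nc4)cc3)oc2c1` carries at that same carbon (6-fluoropyridin-3-yl in place of bromo on an aromatic carbon). Among the compounds with values here, the only measured step, from compound 1 to compound 2, touched this position and stayed within the scatter; nothing measured covers the entry of a second aromatic ring. The account therefore expects for compound 3 a step of a number 4 percentage points higher from compound 2 to compound 3 (within the scatter) that stays near the scatter, with a wide range around it. Compound 3 is estimated at 26%, between 8% and 50%.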

Compound 3, a percentage reported as inhibition, at one concentration (the size of the read-out at that concentration, not a potency): 19%
Compound 3: middle estimate off by 7 percentage points, on the high side; the measured number falls inside the stated range.
By their numbers in this assay, from the lowest: compounds 3, 1 and 2 (each within the scatter of the next).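

Exchanging bromo for 6-fluoropyridin-3-yl, which brings a six-membered aromatic ring, gives in this assay a number 3 percentage points lower from compound 2 to compound 3 (within the scatter) and so shows that this carbon can carry a second aromatic ring without the read-out leaving the scatter. Set against the 2-bromoethoxy group, the same ring gives a number 1 percentage points lower from compound 1 to compound 3 (within the scatter) and thus a halogen, a chain and an aromatic ring at this one carbon all lie within the scatter of each other. No measurement at hand offers an explanation for this flat result.

On these data alone, whether an amine, a carboxylic acid or a longer chain at this carbon would move the number beyond the scatter remains open. With all three values so close, the compounds shown also leave open whether this position matters for the effect at all, or whether changes elsewhere on the shared core would matter more.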